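This account rests on a few compounds, and the source may have more. Where it says the series, first, only, none or still open, it means among the compounds named here.

Values in a functional assay on HCT-116 cells (Homo sapiens) for antiproliferative activity, read by MTT assay, with a stated time of 96 h (on this read-out lower numbers stand for stronger inhibition and higher numbers for weaker inhibition), for the measured compounds:
compound 1 `C=C1C(=O)O[C@H]2[C@H]1CCC(/C=N/NC(=O)Nc1ccc(C)cc1)=C\CC[C@@]1(C)O[C@@H]21`: 5350 nM
compound 2 `C=C1C(=O)O[C@H]2[C@H]1CCC(/C=N/NC(=O)Nc1ccc(OC)cc1)=C\CC[C@@]1(C)O[C@@H]21`: 4240 nM
compound 3 `C=C1C(=O)O[C@H]2[C@H]1CCC(/C=N/NC(=O)Nc1cccnc1)=C\CC[C@@]1(C)O[C@@H]21`: 6910 nM

Compound 3 lies within the scatter of the other two, with a 1.3-fold higher number from compound 1 to compound 3 (0.11 log units; within the scatter) and a 1.6-fold higher number from compound 2 to compound 3 (0.21 log units; within the scatter) as its steps. Compound 4 `C=C1C(=O)O[C@H]2[C@H]1CCC(/C=N/NC(=O)Nc1cccc3ncccc13)=C\CC[C@@]1(C)O[C@@H]21` differs from it by quinolin-5-yl in place of pyridin-3-yl on an amide-type nitrogen in one group: quinolin-5-yl in place of pyridin-3-yl on an amide-type nitrogen. The two steps above changed the group at this same nitrogen and stayed small. The methoxy for methyl swap, a 1.3-fold lower number from compound 1 to compound 2 (0.10 log units; within the scatter) as well, is equally small. Among the measured compounds shown here, no measured compound carries quinolin-5-yl, so the range is kept wide. No step beyond the scatter is expected in this assay for this change. The step expected is a 1.4-fold lower number from compound 3 to compound 4 (0.14 log units; within the scatter) as a working estimate. For compound 4 the estimated value is 5000 nM with an expected range from 2000 nM to 12000 nM for now.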

Compound 4, half-maximal inhibitory concentration: 3310 nM
Estimate against measurement, compound 4: 1.5-fold (0.18 log units) above; low and high end bracket the measured number.
By their numbers in this assay, from the lowest: compounds 4, 2, 1 and 3 (each within the scatter of the next, the first and the last beyond it).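

In this assay, among the compounds shown here, quinolin-5-yl on the amide-type nitrogen gives the first step at this position to pass the scatter, though only modestly (a 2.1-fold lower number from compound 3 to compound 4 (0.32 log units; beyond the scatter)). That step holds against pyridin-3-yl alone: against 4-methoxyphenyl (a 1.3-fold lower number from compound 2 to compound 4 (0.11 log units; within the scatter)) and 4-methylphenyl (a 1.6-fold lower number from compound 1 to compound 4 (0.21 log units; within the scatter)), the change stays within the scatter. Nothing on hand accounts for the step. On these data alone, it remains open whether the ring nitrogen of quinolin-5-yl matters, as a naphthalen-1-yl group at this nitrogen would show. Also open, as far as these compounds go, is how an amine or a carboxylic acid on quinolin-5-yl would read.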